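A few compounds are considered here, and "the series" means these few. Any claim that something is new, unique, unknown or untested is made for them only; others in the source may bear on it.

Compound 1 `COc1cc2c(Oc3ccc(NC(=O)c4nn(-c5ccccc5C)c(=O)cc4C)cc3F)ccnc2cc1OCCCN1CCC(C)CC1` and compound 2 `COc1cc2c(Oc3ccc(NC(=O)c4nn(-c5ccccc5C)c(=O)cc4C)cc3F)ccnc2cc1OCCCN1CCN(C)CC1` share a core and differ only at the far end of the three-carbon chain that hangs from the ring oxygen. In a functional assay on MKN-45 cells (Homo sapiens) for inhibition, read by MTT assay, with a stated time of 72 h (a higher number here means a weaker inhibitor, a lower number a stronger inhibitor), compound 1 gives 1290 nM, and compound 2 gives 1630 nM. Of the two numbers, that of compound 1 is the lower, but the step of a 1.3-fold higher number from compound 1 to compound 2 (0.10 log units; within the scatter) lies within the scatter, so neither compound can be set above the other.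

Compound 3 `COc1cc2c(Oc3ccc(NC(=O)c4nn(-c5ccccc5C(F)(F)F)c(=O)cc4C)cc3F)ccnc2cc1OCCCN1CCC(C)CC1` leaves that chain untouched and changes the aryl ring on the pyridazinone instead: trifluoromethyl in place of methyl on an aromatic carbon. Within the data shown here, no measured step touches this part of the molecule; the single step recorded, from the piperidine to the piperazine, sits on the chain and says nothing about the aryl ring. So the expectation has to rest on compound 1 alone, with the step of a 1.0-fold higher number from compound 1 to compound 3 (0.00 log units; within the scatter) expected to stay within the scatter rather than point in any direction. On that footing compound 3 is estimated at 1300 nM in this assay, with a range from 450 nM to 3900 nM.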

Compound 3, half-maximal inhibitory concentration: 60 nM
Compound 3: the middle estimate sits 22-fold (1.34 log units) above what was measured; measured number below the stated range.
By their numbers in this assay, from the lowest: compound 3; then compounds 1 and 2 (each within the scatter of the next).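

In this assay, among these compounds, the change from 2-methylphenyl to 2-(trifluoromethyl)phenyl gives a 22-fold lower number from compound 1 to compound 3 (1.33 log units; beyond the scatter) and so marks this aromatic carbon, ortho to a large group, as a place where the number can move a long way, whereas the only earlier step, a 1.3-fold higher number from compound 1 to compound 2 (0.10 log units; within the scatter) at the far end of the chain, moved nothing beyond the scatter. The swap adds three fluorine atoms and leaves the counts of rings, hydrogen-bond donors and acceptors and the net charge unchanged, so a large step here comes without any change in those counts. No measurement at hand accounts for the size of this step.

On these data alone, whether the drop in the number belongs to trifluoromethyl itself remains open, as does whether chlorine, methoxy or a nitrile on the same carbon would land nearer compound 1 or compound 3. Also open is whether the same change would carry over to compound 2 with its 4-methylpiperazin-1-yl chain end, as the compounds shown test it only with the 4-methylpiperidin-1-yl chain end of compound 1.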